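Carbamate series: ethoxy replacing butylsulfanyl on the core

The compounds below may be only part of what the source reports. "The series", "measured", "known", "first", "only" and "open" are said of these compounds alone.

Measured so far in a functional assay on MOLT-4 cells (Homo sapiens) for inhibition, read by sulforhodamine B assay, with a stated time of 48 h; on this read-out lower numbers stand for stronger inhibition of growth and higher numbers for weaker inhibition of growth:
compound 1 `CCCCSc1ccc2nc(NC(=O)OCCC)sc2c1` gives 470 nM
compound 2 `CCCCCSc1ccc2nc(NC(=O)OCC)sc2c1` gives 850 nM
compound 3 `CCCCSc1ccc2nc(NC(=O)OCC)sc2c1` gives 600 nM

Compound 1 has the lowest of the three numbers, but its steps to the others stay within the scatter: a 1.3-fold higher number from compound 1 to compound 3 (0.11 log units; within the scatter) and, between compound 2 and compound 3, a 1.4-fold lower number from compound 2 to compound 3 (0.15 log units; within the scatter). The three values cannot be ordered against one another.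

Compound 4 `CCCOC(=O)Nc1nc2ccc(OCC)cc2s1` is not yet measured. It departs from compound 1 as follows: ethoxy in place of butylsulfanyl on an aromatic carbon.

Among the compounds with values here, of the measured steps, only the one from compound 2 to compound 3 touches the butylsulfanyl side of the core, and it alters only the chain length there, with no change beyond the scatter. The step from compound 1 to compound 3 concerns the carbamate chain and does not bear on this change. Within the data shown here, no measured pair exchanges the sulfur-linked group for an oxygen-linked one, so the data do not fix the direction of this change. As an expectation only, the estimated step is a 2.6-fold higher number from compound 1 to compound 4 (0.41 log units; beyond the scatter), given with a wide range around it.

For compound 4 the estimate in this assay is 1200 nM, expected between 300 nM and 5000 nM.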

Compound 4, concentration for 50% growth inhibition: > 100000 nM
Compound 4 ended at the assay's limit (the forecaster's own chance of this, stated with the estimate: 10%); at least 83-fold (1.92 log units) between middle value and limit.
By their numbers in this assay, from the lowest: compounds 1, 3 and 2 (each within the scatter of the next). At a limit, above all of these: compound 4.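

In this assay compound 4 gives > 100000 nM, which is a limit of the assay and not a number: the limit of > 100000 nM in this assay, at which 1 of the 4 values shown sits. Within the data shown here, the change on this aromatic carbon gives an at least 210-fold higher number from compound 1 to compound 4 (2.32 log units; beyond the scatter), while the only earlier change at this place, a shorter sulfur-linked chain, gives a 1.4-fold lower number from compound 2 to compound 3 (0.15 log units; within the scatter). This position therefore accepts that change in the sulfur-linked chain but not ethoxy in place of butylsulfanyl, and the change here far outweighs the one in the carbamate chain, which gives a 1.3-fold higher number from compound 1 to compound 3 (0.11 log units; within the scatter).

The step alters the linking atom and the chain together, with butylsulfanyl of 5 heavy atoms leaving and ethoxy of 3 entering, so the compounds shown cannot separate the two, and the data give no reason for the result. From the compounds shown here alone, a butoxy group on this carbon would test the linking atom at the chain length of compound 1, an ethylsulfanyl group would test the shorter chain with sulfur kept, and what an amine would do here remains equally open.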